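Swapping Fluoro for Cyano on the Amine-Linked Ring

The compounds below may be only part of what the source reports. "The series", "measured", "known", "first", "only" and "open" are said of these compounds alone.

Going by the values given here, compound 2 `Fc1ccc(Nc2cc3[nH]c(-c4cccc(C(F)(F)F)c4)nc3cn2)nc1` is the more stable of the two compounds measured so far. In an ADME assay on microsomes from liver (Mus musculus) for metabolic stability, read by LC-MS, with a stated time of 30 min, tested at 0.1 uM (a higher number here means that more of the compound is left, a lower number that less of the compound is left), compound 2 gives 54%, whereas compound 1 `FC(F)(F)c1cccc(-c2nc3cnc(Nc4cnccn4)cc3[nH]2)c1` gives 7%. Among the compounds with values here, the only measured step, a number 47 percentage points higher from compound 1 to compound 2 (beyond the scatter), shows that exchanging the ring attached to the amine nitrogen can move this assay strongly. Compound 3 `N#Cc1ccc(Nc2cc3[nH]c(-c4cccc(C(F)(F)F)c4)nc3cn2)nc1` differs from compound 2 in one place: cyano in place of fluoro on an aromatic carbon. Within the data shown here, no measured step shows what exchanging fluoro for cyano does here; the one known step concerns a different change, the exchange of one whole ring for another, so it bears only loosely on this one. With nothing closer to lean on, the expectation is for no step beyond the usual scatter, though the range is kept wide. The step expected in this assay is a number 9 percentage points lower from compound 2 to compound 3 (within the scatter). The estimated value for compound 3 in this assay is therefore 45%, with a range from 20% to 70%.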

Compound 3, percent of the compound remaining: 47%
Compound 3: middle estimate off by 2 percentage points, on the low side, within the range that was stated.
By their numbers in this assay, from the lowest: compound 1; then compounds 3 and 2 (each within the scatter of the next).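

At this place on the pyridine ring, para to a large group and two atoms from the ring nitrogen, this assay shows a number 7 percentage points lower from compound 2 to compound 3 (within the scatter) when fluoro is replaced by cyano, so this read-out does not separate the two groups. Going by these compounds alone, the earlier comparison had only one substituted ring, which left open whether the higher number depended on fluoro; with 5-cyanopyridin-2-yl in place of pyrazin-2-yl, the result is a number 40 percentage points higher from compound 1 to compound 3 (beyond the scatter) and so the large rise also appears with a second group, alongside a number 47 percentage points higher from compound 1 to compound 2 (beyond the scatter) for the 5-fluoropyridin-2-yl ring. Nothing available here explains why either ring change raises the number or why the exchange of fluoro for cyano leaves it within the scatter.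

The compounds shown carry only fluoro or cyano at this place, so it remains open what a methoxy group, an amine or a plain hydrogen would do there. They also all keep the trifluoromethyl-bearing ring unchanged, so it cannot be said whether fluoro and cyano would still match with a different group on that ring.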